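The source may report more compounds than this note shows. Statements on the series, on what has been measured and on what is new or still open speak of the compounds shown alone.

Compound 1 (`Cc1ccc(C)c(S(=O)(=O)N(C)/N=C/c2cnn3ccc(C#N)cc23)c1`) is the starting point. In an assay on isolated protein for inhibition of phosphatidylinositol 4,5-bisphosphate 3-kinase catalytic subunit beta isoform (Homo sapiens), read by 33P incorporation, with a stated time of 60 min (a lower number here means a stronger inhibitor, a higher number a weaker inhibitor), compound 1 gives > 1000 nM, which is a limit of the measurement and not a number. Two related compounds were measured with it. Compound 2 (`Cc1ccc([N+](=O)[O-])cc1S(=O)(=O)N(Cc1ccccc1)/N=C/c1cnn2ccc(C#N)cc12`) also reaches only a limit in this assay, giving > 1000 nM. Compound 3 (`CC(C)c1ccc([N+](=O)[O-])cc1S(=O)(=O)N(C)/N=C/c1cnn2ccc(C#N)cc12`) gives 300 nM in this assay. Among the compounds with values here, compound 1 therefore stands at the limit of > 1000 nM in this assay, at which 2 of the 3 values shown sit, and among the three values only that of compound 3 is a number.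

Compound 4 (`Cc1ccc(NC(=O)C(F)(F)F)cc1S(=O)(=O)N(C)/N=C/c1cnn2ccc(C#N)cc12`) has not been measured yet. It differs from compound 1 in one place: ((trifluoromethyl)carbonyl)amino in place of methyl on an aromatic carbon. Within the data shown here, no two of the measured compounds differ in only one place, so no measured step gives the size of such a change. The values shown do not tell whether this exchange moves the number in either direction, so no step beyond the scatter is expected with any confidence, and the estimate for the step is a step that the limit leaves unreadable from compound 1 to compound 4. Compound 4 is therefore expected to give about 1500 nM in this assay, with a range from 300 nM to 8000 nM, and it may well again return only a limit.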

Compound 4, half-maximal inhibitory concentration: > 1000 nM
Compound 4: a limit, no number; the forecaster's own chance of this, stated with the estimate: 55%; the middle value does not contradict the limit.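

In this assay compound 4 gives > 1000 nM, which is a limit and not a number. Compound 1 gives > 1000 nM, also a limit. Within the data shown here, no step between compound 1 and compound 4 can therefore be read, and most values shown sit at that same point: the limit of > 1000 nM in this assay, at which 3 of the 4 values shown sit. As far as these compounds go, whether ((trifluoromethyl)carbonyl)amino in place of methyl strengthens or weakens inhibition, and by how much, stays open.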